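A few compounds are considered here, and "the series" means these few. Any claim that something is new, unique, unknown or untested is made for them only; others in the source may bear on it.

Among the compounds with values here, compound 3, `CN(C)c1nc(N[C@H]2CC[C@@H](NC(=O)c3ccc(F)cc3)CC2)nc2ccccc12`, is one of three compounds measured in an assay on HEK293 cells for inhibition of melanin-concentrating hormone receptor 1 (Homo sapiens), read by radioligand binding; on this read-out higher numbers stand for weaker inhibition and lower numbers for stronger inhibition. In that assay compound 3 gives 9.4 nM, the lowest of the three numbers. Compound 1, `CN(C)c1nc(N[C@H]2CC[C@@H](NC(=O)c3cccc(C#N)c3)CC2)nc2ccccc12`, gives 10 nM, and the two values sit within the usual scatter of each other. Compound 2, `CN(C)c1nc(NCC2CCC(CNC(=O)c3ccc(Br)cc3OC(F)(F)F)CC2)nc2ccccc12`, differs from both in more than one place and gives 1500 nM, far away from the others.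

Compound 4, `CN(C)c1nc(N[C@H]2CC[C@@H](NC(=O)c3ccccc3F)CC2)nc2ccccc12`, has not yet been measured. It shares every atom with compound 3, joined differently: 2-fluorophenyl in place of 4-fluorophenyl on a carbonyl carbon.

Within the data shown here, only one measured step concerns a change on the same carbonyl carbon: a 1.1-fold lower number from compound 1 to compound 3 (0.03 log units; within the scatter). That change swapped a whole substituted ring for another and left the number essentially where it was. Among the measured compounds shown here, no measured pair shows a fluorine moved from one position of the ring to another, so the present change is not covered directly. For the measured compounds named here, the one related step suggests the amide-bound ring tolerates variation, and the shared core is unchanged. The expected outcome is therefore a step of a 2.1-fold higher number from compound 3 to compound 4 (0.33 log units; beyond the scatter), a small shift that may well stay inside the scatter. For compound 4 the estimate in this assay is 20 nM, with a range from 6 nM to 70 nM.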

Compound 4, half-maximal inhibitory concentration: 170 nM
Estimate against measurement, compound 4: 8.5-fold (0.93 log units) below, outside the stated range (above it).
By their numbers in this assay, from the lowest: compounds 3 and 1 (each within the scatter of the next); then compound 4; then compound 2.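

In this assay, where the fluorine sits on the ring attached to the carbonyl carbon matters a great deal: 2-fluorophenyl in place of 4-fluorophenyl gives an 18-fold higher number from compound 3 to compound 4 (1.26 log units; beyond the scatter), even though the two compounds contain the same atoms. The earlier compounds suggested that this ring could vary freely, with a 1.1-fold lower number from compound 1 to compound 3 (0.03 log units; within the scatter), but replacing 3-cyanophenyl with 2-fluorophenyl gives a 17-fold higher number from compound 1 to compound 4 (1.23 log units; beyond the scatter), so among these three rings on the same scaffold, 2-fluorophenyl alone stands apart. No measurement here explains why moving the fluorine has so large an effect.

The compounds shown leave open whether this large step is specific to fluorine or also appears with other groups at that ring position, as in 2-chlorophenyl or 2-methoxyphenyl. They also leave open how plain phenyl, with no substituent, and 3-fluorophenyl, with the fluorine at the remaining ring position, would compare with compound 3 and compound 4 in this assay.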